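Hydroxy for amino on two cores: cytotoxicity notes

This account rests on a few compounds, and the source may have more. Where it says the series, first, only, none or still open, it means among the compounds named here.

Measured so far in an ADME assay on L1210/0 cells (Mus musculus) for cytotoxicity, with a stated time of 48 h; on this read-out higher numbers stand for weaker inhibition and lower numbers for stronger inhibition:
- compound 1 `Nc1nc(N)c2ncn([C@H]3CCCC[C@H]3CO)c2n1`: > 200000 nM, a limit of the assay
- compound 2 `Nc1nc(N)c2nnn([C@H]3CCCC[C@H]3CO)c2n1`: > 200000 nM, a limit of the assay
- compound 3 `Nc1nc(O)c2ncn([C@H]3CCCC[C@H]3CO)c2n1`: > 200000 nM, a limit of the assay

All three values sit at the limit (the limit of > 200000 nM in this assay, at which 3 of the 3 values shown sit), so no number is known for any of them. The change from compound 1 to compound 3 is hydroxy in place of amino on an aromatic carbon, and its step that the two limits leave unreadable from compound 1 to compound 3 cannot be read, both ends being limits. The difference between the core of compound 1 and the core of compound 2 is not broken down here.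

Compound 4 `Nc1nc(O)c2nnn([C@H]3CCCC[C@H]3CO)c2n1` is the not yet measured partner: the change from compound 2 to compound 4 is hydroxy in place of amino on an aromatic carbon, the same change as from compound 1 to compound 3, the place being described in identical words.

For compound 4 the estimate in this assay is 250000 nM, within 150000 nM to 600000 nM. The estimated step that the limit leaves unreadable from compound 2 to compound 4 rests on the limit of > 200000 nM in this assay, at which 3 of the 3 values shown sit, at which every measured member of the series sits, so another limit rather than a number is expected.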

Compound 4, half-maximal inhibitory concentration: > 200000 nM
Compound 4 ended at the assay's limit; the forecaster's own chance of this, stated with the estimate: 90%; the middle value lies beyond the limit too.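

Compound 2 and compound 4 both end at a limit of the assay, so the step between them cannot be read, and this pair adds no new step: the limit of > 200000 nM in this assay, at which 4 of the 4 values shown sit.

With no number for any compound shown, it stays open whether hydroxy in place of amino on an aromatic carbon alters cytotoxicity on either core.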